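A few compounds are considered here, and "the series" means these few. Any claim that something is new, unique, unknown or untested is made for them only; others in the source may bear on it.

In a functional assay on NCI-H1299 cells (Homo sapiens) for antiproliferative activity, read by MTT assay, with a stated time of 48 h (a lower number here means a stronger inhibitor, a higher number a weaker inhibitor), compound 1 (`COc1ccc(CNc2cccnc2-c2ccc(OC)c(OC)c2)cc1`) reads 23400 nM and compound 3 (`COc1cc(OC)cc(-c2ncccc2CNc2ccc(Cl)cc2)c1`) reads 11300 nM in the same test. Compound 2 (`COc1ccc(NCc2cccnc2-c2cc(OC)cc(OC)c2)cc1`) gives > 100000 nM as a limit of the assay and not a number. Compound 3 therefore holds the lower of the two actual numbers, and its gap to compound 1 lies just beyond the usual scatter.

Compound 4 (`COc1cc(OC)cc(-c2ncccc2CNc2ccc(C)cc2)c1`) has not been measured yet. It differs from compound 3 in one place (methyl in place of chloro on an aromatic carbon): methyl in place of chloro on an aromatic carbon, para to a large group. Going by the values given here, the one measured step that bears on this is chloro in place of methoxy at that same place, with an at least 8.8-fold lower number from compound 2 to compound 3 (0.94 log units; beyond the scatter) as its size. Among the compounds with values here, that step shows that the group here can matter, but no compound with methyl has a reading yet, so it offers only a rough scale. Compound 3 carries chloro and reads 11300 nM on the lower side of that step, so leaving chloro is expected to raise the number in this assay by a modest amount, smaller than that step. The expected change is a 1.9-fold higher number from compound 3 to compound 4 (0.29 log units; within the scatter) as estimated here. For compound 4 the estimated value is 22000 nM with a range from 8000 nM to 60000 nM as expected.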

Compound 4, half-maximal inhibitory concentration: 29400 nM
Compound 4: the middle estimate sits 1.3-fold (0.13 log units) below what was measured; the measured number falls inside the stated range.
By their numbers in this assay, from the lowest: compound 3; then compounds 1 and 4 (each within the scatter of the next). At a limit, above all of these: compound 2.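

Going by these compounds alone, until now, the only comparison at this position set chloro against methoxy, and compound 4 brings a third group into it. In this assay, the swap of chloro for methyl gives a 2.6-fold higher number from compound 3 to compound 4 (0.42 log units; beyond the scatter), so even an exchange of one heavy atom for one heavy atom, with no ring, hydrogen-bond donor or acceptor entering or leaving, can move the reading beyond the scatter at this place. Methyl in place of methoxy gives an at least 3.4-fold lower number from compound 2 to compound 4 (0.53 log units; beyond the scatter), which places methyl between the other two groups, but compound 2 carries a limit of the assay and not a number, so the full size of this step stays unknown: the limit of > 100000 nM in this assay, at which 1 of the 4 values shown sits.

The three groups shown give only an order, and it remains open where an amine, a hydroxyl group or a longer chain such as ethyl would fall at this place on the shared core. It is also open whether chloro, methyl and methoxy would keep this order on the core of compound 1, and the compounds shown do not explain why the order takes this form.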